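Pyrimidinyl replacement on the fused core: notes toward compound 4

This account rests on a few compounds, and the source may have more. Where it says the series, first, only, none or still open, it means among the compounds named here.

Measured so far:
compound 1, `OCc1ccc(-c2nn(Cc3cccc(F)c3)c3ccccc23)o1`, 10000 nM
compound 2, `OCc1ccc(-c2nn(Cc3ccccc3F)c3ncncc23)o1`, 9400 nM
compound 3, `OCc1ccnc(-c2nn(Cc3ccccc3F)c3ncccc23)n1`, 1300 nM

In a functional assay (aorta) with Oryctolagus cuniculus as the target (a higher number here means a weaker inhibitor, a lower number a stronger inhibitor), compound 1 gives 10000 nM and compound 2 gives 9400 nM, both toward the weak end of what the series has shown. In this assay compound 3 gives 1300 nM, the lowest of the three numbers; its gap to compound 2, the nearest, and to compound 1, the furthest, each lies beyond the usual scatter, so compound 3 is the strongest inhibitor among the three.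

Compound 4, `Nc1nc(-c2nn(Cc3ccccc3F)c3ncccc23)ncc1F`, has not yet been measured. It differs from compound 3 in one place: 4-amino-5-fluoropyrimidin-2-yl in place of 4-(hydroxymethyl)pyrimidin-2-yl on an aromatic carbon. For the measured compounds named here, no measured pair shows this change, so its effect cannot be read from the series. The expectation for compound 4 is a moderate step toward a lower number, a 3.3-fold lower number from compound 3 to compound 4 (0.51 log units; beyond the scatter), though a step within the scatter is not excluded. Compound 4 is thus estimated at 400 nM in this assay, with a range from 100 nM to 2000 nM.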

Compound 4, half-maximal inhibitory concentration: 478000 nM
Compound 4: middle estimate off by 1200-fold (3.08 log units), on the low side, outside the stated range (above it).
By their numbers in this assay, from the lowest: compound 3; then compounds 2 and 1 (each within the scatter of the next); then compound 4.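

In this assay, for the compounds shown here, 4-amino-5-fluoropyrimidin-2-yl in place of 4-(hydroxymethyl)pyrimidin-2-yl gives a 370-fold higher number from compound 3 to compound 4 (2.57 log units; beyond the scatter), the first step that changes one place only. The number at this aromatic carbon of the five-membered ring therefore depends strongly on what the pyrimidine ring carries, even though the leaving and entering groups match in every count of heavy atoms, donors, acceptors and net charge. Nothing on hand explains the size of this step.

The step combines two substituent changes, so the compounds shown cannot say whether the amine without the fluorine, or the fluorine with the hydroxymethyl kept, would read closer to compound 3 or to compound 4. Also open, from the compounds shown here alone, is how a carboxylic acid or a longer chain in place of the hydroxymethyl would read in this assay.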